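Moving the Methyl Group on the Carboxyphenyl End

A few compounds are considered here, and "the series" means these few. Any claim that something is new, unique, unknown or untested is made for them only; others in the source may bear on it.

Measured so far in an ADME assay (liver) for metabolic stability, with Liver microsome (Rattus norvegicus) as the target, read by LC-MS, using microsomes and NADPH, with stated times of 5 min and 60 min, tested at 4 uM; on this read-out lower numbers stand for a less stable compound and higher numbers for a more stable compound:
compound 1, `Cc1cc(C(=O)O)ccc1OCCCCOc1ccc(C(=O)CC(C)C)c(O)c1C`, gives 41%
compound 2, `Cc1cc(OCCCCOc2ccc(C(=O)CC(C)C)c(O)c2C)ccc1C(=O)O`, gives 57%
compound 3, `Cc1cc(C(=O)O)ccc1OCCCCOc1ccc(C(=O)CC2CCCC2)c(O)c1C`, gives 59%

Compound 4, `Cc1cc(OCCCCOc2ccc(C(=O)CC3CCCC3)c(O)c2C)ccc1C(=O)O`, has not yet been measured.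

Compound 1 and compound 2 differ by 4-carboxy-3-methylphenyl in place of 4-carboxy-2-methylphenyl on an oxygen on a saturated carbon, and this change brought a number 16 percentage points higher from compound 1 to compound 2 (beyond the scatter). The cores of compound 1 and compound 3 differ by cyclopentyl in place of isopropyl on a saturated chain carbon bound to a carbonyl carbon, a change that brought a number 18 percentage points higher from compound 1 to compound 3 (beyond the scatter). Compound 3 and compound 4 differ by 4-carboxy-3-methylphenyl in place of 4-carboxy-2-methylphenyl on an oxygen on a saturated carbon, at the same place as before, so it is the same change made on the other core.

Compound 3 is within the scatter of compound 2, so no order between them is claimed. Within the data shown here, with only one earlier example of this change, the expectation for compound 4 in this assay is a step of a number 12 percentage points higher from compound 3 to compound 4 (beyond the scatter), resting on compound 1 to compound 2 showing a number 16 percentage points higher from compound 1 to compound 2 (beyond the scatter) and on compound 3 already sitting at 59%. Compound 4 is therefore estimated to give 71%, with a range from 56% to 85%.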

Compound 4, percent of the compound remaining: 55%
Compound 4: the middle estimate sits 16 percentage points above what was measured; measured number outside the range, below it.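

On the core carrying cyclopentyl, 4-carboxy-3-methylphenyl in place of 4-carboxy-2-methylphenyl gave a number 4 percentage points lower from compound 3 to compound 4 (within the scatter) in this assay and so did not repeat the rise seen on the core carrying isopropyl: the same change on two cores in this assay, a number 16 percentage points higher (beyond the scatter) from compound 1 to compound 2 and a number 4 percentage points lower (within the scatter) from compound 3 to compound 4, 20 percentage points apart, beyond the scatter of two such steps.

The other change behaves the same way, since cyclopentyl in place of isopropyl gave a number 2 percentage points lower from compound 2 to compound 4 (within the scatter) once the 4-carboxy-3-methylphenyl group was present, unlike its earlier rise on the other core: the same change on two cores in this assay, a number 18 percentage points higher (beyond the scatter) from compound 1 to compound 3 and a number 2 percentage points lower (within the scatter) from compound 2 to compound 4, 20 percentage points apart, beyond the scatter of two such steps.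

Across these four compounds, then, the two changes do not add up, and the effect of each depends on what the rest of the molecule carries, but this does not show why, and a single pair of cores gives no general rule for other cores.

The compounds shown leave open whether the same behaviour would appear with cyclohexyl in place of cyclopentyl or with an amide in place of the carboxylic acid. They also do not tell which part of each compound is altered during the incubation.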